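Swapping a Hydroxymethyl for a Fluoromethyl on the Chain

A few compounds are considered here, and "the series" means these few. Any claim that something is new, unique, unknown or untested is made for them only; others in the source may bear on it.

Compound 3 `COc1cc(C(c2ccc(O)c(OC)c2)[C@@H](C)[C@@H](C)CO)ccc1O` carries a 2-(hydroxymethyl)-1-methylpropyl group on the saturated chain carbon bound to two aromatic carbons. In a functional assay on HeLa cells (Homo sapiens) for cytotoxicity, read by WST assay, with a stated time of 48 h (on this read-out higher numbers stand for weaker inhibition and lower numbers for stronger inhibition), compound 3 gives > 100000 nM, which is a limit of the assay and not a number (the limit of > 100000 nM in this assay, at which 1 of the 3 values shown sits). Compound 4 `COc1cc(C(c2ccc(O)c(OC)c2)[C@@H](CF)C(C)C)ccc1O` differs from it in one place: 1-(fluoromethyl)-2-methylpropyl in place of 2-(hydroxymethyl)-1-methylpropyl on a saturated chain carbon bound to two aromatic carbons. Among the compounds with values here, two measured steps bear on this change. Compound 2 `COc1cc(C(c2ccc(O)c(OC)c2)[C@@H](C)[C@H](C)CF)ccc1O` gives 37000 nM, and the step of an at least 2.7-fold higher number from compound 2 to compound 3 (0.43 log units; beyond the scatter) shows that trading a fluoromethyl for a hydroxymethyl pushed the number up to the limit. Compound 1 `COC[C@H](C(C)C)C(c1ccc(O)c(OC)c1)c1ccc(O)c(OC)c1` gives 76000 nM, and the step of a 2.1-fold lower number from compound 1 to compound 2 (0.31 log units; beyond the scatter) again leaves the fluoromethyl compound with the lower number. Only these three compounds are known, so no wider pattern can be claimed, and the 1-(fluoromethyl)-2-methylpropyl chain of compound 4 resembles the chain of compound 1 more closely than that of compound 2. A modest fall in the number is therefore expected, an at least 2.0-fold lower number from compound 3 to compound 4 (0.30 log units; that floor lies within the scatter). Compound 4 is expected to give about 50000 nM, with a range from 20000 nM to 120000 nM.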

Compound 4, half-maximal inhibitory concentration: 41000 nM
Estimate against measurement, compound 4: 1.2-fold (0.09 log units) above; low and high end bracket the measured number.
By their numbers in this assay, from the lowest: compounds 2, 4 and 1 (each within the scatter of the next, the first and the last beyond it). At a limit, above all of these: compound 3.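

Compound 3 stands at a limit of the assay and not at a number: the limit of > 100000 nM in this assay, at which 1 of the 4 values shown sits.

Even so, in this assay the change gives an at least 2.4-fold lower number from compound 3 to compound 4 (0.38 log units; beyond the scatter), so the fluorine-bearing chain on this saturated chain carbon reads clearly lower than the 2-(hydroxymethyl)-1-methylpropyl chain. The new result also shows that the two fluorine-bearing chains cannot be told apart, with a 1.1-fold higher number from compound 2 to compound 4 (0.04 log units; within the scatter), and that a 1.9-fold lower number from compound 1 to compound 4 (0.27 log units; within the scatter) leaves the 1-(fluoromethyl)-2-methylpropyl chain no clearer of the methoxymethyl chain.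

On these data alone, the full size of the step from compound 3 stays open, as only a limit is available for it. The compounds shown also leave open how a chain ending in an amine or a carboxylic acid, or a longer chain, would read at this position.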